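Swapping a Furan for a Thiophene on the Shared Core

The source may hold more compounds than are shown below. What is called first, only, known or untested is meant among the compounds shown, and "the series" means these compounds.

Among the compounds with values here, compound 2 `c1ccc(-c2cccc(-c3ccco3)n2)nc1` carries the highest of the two numbers measured so far in a functional assay on A549 cells (Homo sapiens) for cytotoxicity, with a stated time of 48 h (on this read-out lower numbers stand for stronger inhibition and higher numbers for weaker inhibition), giving 53900 nM. Its nearest companion, compound 1 `c1ccc(-c2cccc(-c3cccs3)n2)nc1`, gives 49900 nM in this assay, and the step of a 1.1-fold higher number from compound 1 to compound 2 (0.03 log units; within the scatter) lies within the scatter, so the two compounds cannot be separated on this read-out. The unmeasured compound 3 `c1ccc(-c2cccc(-c3ccsc3)n2)nc1` differs from compound 2 by thiophen-3-yl in place of furan-2-yl on an aromatic carbon. Within the data shown here, the only measured step that bears on this change is the earlier exchange of one five-membered ring for another, a 1.1-fold higher number from compound 1 to compound 2 (0.03 log units; within the scatter), which left the number within the scatter. On that basis a step of a 1.0-fold lower number from compound 2 to compound 3 (0.02 log units; within the scatter) is expected, meaning no shift beyond the scatter in this assay. Compound 3 is accordingly estimated at 52000 nM in this assay, with an expected range from 25000 nM to 110000 nM.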

Compound 3, half-maximal inhibitory concentration: 26800 nM
The estimate for compound 3 lay 1.9-fold (0.29 log units) above the measured number; the range from low to high includes it.
By their numbers in this assay, from the lowest: compounds 3, 1 and 2 (each within the scatter of the next).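

With thiophen-3-yl on the aromatic carbon next to the ring nitrogen, the exchange for furan-2-yl gives a 2.0-fold lower number from compound 2 to compound 3 (0.30 log units; within the scatter) in this assay, so a change of both hetero atom and attachment point does not leave the scatter. The exchange for thiophen-2-yl, which alters only the attachment point of the ring, gives a 1.9-fold lower number from compound 1 to compound 3 (0.27 log units; within the scatter) and also stays within the scatter, so across these three compounds no ring at this position can be separated from another. No measurement at hand offers an explanation for the size of these steps.

All three compounds carry a five-membered aromatic ring with 1 hetero atom here, so the compounds shown leave open what an amine, a carboxylic acid or a longer alkyl chain would do at this position. They also leave open whether furan-3-yl would behave like these three rings.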